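A few compounds are considered here, and "the series" means these few. Any claim that something is new, unique, unknown or untested is made for them only; others in the source may bear on it.

Measured so far in a functional assay on A549 cells (Homo sapiens) for cytotoxicity, read by MTT assay, with a stated time of 48 h; a lower number here means a stronger inhibitor, a higher number a weaker inhibitor:
- compound 1 `CCOC(=O)C1=C(C)NC(=S)NC1c1cccc(OCCCCOc2cccc(C3NC(=S)NC(C)=C3C(=O)OCC)c2)c1`: > 200 ug/mL
- compound 2 `CCOC(=O)C1=C(C)NC(=S)NC1c1cccc(OC/C=C\COc2cccc(C3NC(=S)NC(C)=C3C(=O)OCC)c2)c1`: 154 ug/mL

Compound 1 gives > 200 ug/mL, which is a limit of the assay and not a number. Among the measured compounds shown here, compound 2, at 154 ug/mL, holds the only actual number so far, so there is little to compare it with.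

The next compound, compound 3 `CCOC(=O)C1=C(C)NC(=S)NC1c1cccc(OC/C=C/COc2cccc(C3NC(=S)NC(C)=C3C(=O)OCC)c2)c1`, has the same atoms and bonds as compound 2. The sole difference is one of geometry: the two compounds have the same atoms and bonds; at least one stereo element is drawn with a configuration in one of them and without one in the other: 1 of 3 stereo elements differ; a double bond is drawn Z in compound 2 and E in compound 3.

For the measured compounds named here, no measured pair of compounds shows what such a switch does in this assay. The expectation is therefore no step beyond the usual scatter, and no particular direction, with compound 2 at 154 ug/mL as the anchor. The expected change is small, a 1.0-fold higher number from compound 2 to compound 3 (0.02 log units; within the scatter). For compound 3 the estimated value is 160 ug/mL, with an expected range of 85 ug/mL to 200 ug/mL.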

Compound 3, half-maximal inhibitory concentration: > 200 ug/mL
Compound 3: only a limit was reported; the forecaster's own chance of this, stated with the estimate: 25%; at least 1.2-fold (0.09 log units) between middle value and limit.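

In this assay compound 3 gives > 200 ug/mL, which is a limit of the assay and not a number. Turning the double bond in the chain from Z to E can now be read as a step, an at least 1.2-fold higher number from compound 2 to compound 3 (0.11 log units; that floor lies within the scatter), so this one switch separates a measured number from a limit, although the smallest step it allows does not clear the usual scatter. The true size of the step cannot be read, and the reason lies in the limit itself: the limit of > 200 ug/mL in this assay, at which 2 of the 3 values shown sit.

The compounds shown leave open whether the geometry of this bond matters at all in this assay, or whether a triple bond or a longer chain in its place would give a clearly lower number. Going by these compounds, it also remains open how far replacing the ester with a carboxylic acid or an amide would change the picture.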